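A few compounds are considered here, and "the series" means these few. Any claim that something is new, unique, unknown or untested is made for them only; others in the source may bear on it.

Of the compounds shown here, three have been tested so far in a functional assay on NCI-H460 cells (Homo sapiens) for cytotoxicity, read by MTT assay (a higher number here means a weaker inhibitor, a lower number a stronger inhibitor), and a fourth awaits measurement. Compound 1 `COc1cccc(/C=C/C(=O)c2sc(Nc3cccc(C)c3)nc2C)c1` and compound 2 `COc1cccc(/C=C/C(=O)c2sc(Nc3ccccc3C)nc2C)c1` share one core and differ only in the group carried by the nitrogen: 3-methylphenyl in place of 2-methylphenyl on a nitrogen on an aromatic ring. In this assay compound 1 gives > 25000 nM, which is a limit of the assay rather than a number. Compound 2 likewise gives > 25000 nM, also a limit. The step between them, a step that the two limits leave unreadable from compound 2 to compound 1, therefore cannot be read in either direction, owing to the limit of > 25000 nM in this assay, at which 2 of the 3 values shown sit.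

Compound 3 `COc1cc(/C=C/C(=O)c2sc(Nc3ccccc3C)nc2C)cc(OC)c1OC` carries the same 2-methylphenyl group as compound 2 but differs from it elsewhere; the difference between the two cores is not broken down here. In this assay, among the compounds with values here, compound 3 gives 6320 nM, the only actual number among the three.

Compound 4 `COc1cc(/C=C/C(=O)c2sc(Nc3cccc(C)c3)nc2C)cc(OC)c1OC` is the unmeasured partner of compound 3, related to it by the same change that links compound 2 to compound 1: 3-methylphenyl in place of 2-methylphenyl on a nitrogen on an aromatic ring. The place of the change reads the same in both pairs, so this is the same change. Within the data shown here, its one measured instance is unreadable, and so its size is unknown. The expectation for compound 4 can therefore rest only on compound 3 and its value of 6320 nM. The expected step is a 1.3-fold higher number from compound 3 to compound 4 (0.10 log units; within the scatter), a shift small enough to stay within the usual scatter. Compound 4 is thus estimated at 8000 nM in this assay, with a likely range from 2500 nM to 25000 nM, and with a real chance that only a limit is reported.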

Compound 4, half-maximal inhibitory concentration: 19800 nM
Compound 4: the middle estimate sits 2.5-fold (0.39 log units) below what was measured; low and high end bracket the measured number.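

In this assay, putting 3-methylphenyl in place of 2-methylphenyl on the nitrogen gives a 3.1-fold higher number from compound 3 to compound 4 (0.50 log units; beyond the scatter), so on this core the change goes with a modest but real weakening, even though the two groups have the same atoms and differ only in how they are joined. This is a single readable instance of the change, and it describes one core only; it does not establish a rule that can be carried to other cores, and it does not explain why the weakening occurs. The same change on the core shared by compound 1 and compound 2 gives no second size or direction to compare, and the steps there cannot be read because both compounds sit at an assay limit rather than at a number: the limit of > 25000 nM in this assay, at which 2 of the 4 values shown sit.

The compounds shown leave open how this part of the series responds to anything other than a methylphenyl group on the nitrogen, such as a chlorophenyl group, or a phenyl group carrying an amine or a carboxylic acid. They also leave open whether the step seen here would hold in any other cell line.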